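The source may hold more compounds than are shown below. What is called first, only, known or untested is meant among the compounds shown, and "the series" means these compounds.

Measured so far in an ADME assay on the whole organism with Oryza sativa as the target, tested at 1 uM; a lower number here means a stronger effect, a higher number a weaker effect of the compound at the concentration tested:
compound 1 `CCc1ccc(NC(=O)N[C@@H](C)c2ccccc2)cc1`: 95%
compound 2 `CCCCc1ccc(NC(=O)N[C@@H](C)c2ccccc2)cc1`: 72%
compound 3 `CCCCCc1ccc(NC(=O)N[C@@H](C)c2ccccc2)cc1`: 98%

Compound 3 gives the highest number of the three; compound 1 lies within the scatter of it, and compound 2 stands furthest off, as seen in a number 26 percentage points higher from compound 2 to compound 3 (beyond the scatter). The chain-length steps do not run one way: a number 23 percentage points lower from compound 1 to compound 2 (beyond the scatter), whereas a number 3 percentage points higher from compound 1 to compound 3 (within the scatter).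

Compound 4 `C[C@H](NC(=O)Nc1ccc(C(F)(F)F)cc1)c1ccccc1` differs from compound 3 by trifluoromethyl in place of pentyl on an aromatic carbon. Within the data shown here, no measured step exchanges a chain for trifluoromethyl; the chain steps are the only guide, and they are modest and of opposite sign. Hence no step beyond the scatter is expected in this assay, a number 8 percentage points lower from compound 3 to compound 4 (within the scatter). For compound 4 the estimate is 90%, with an expected range from 68% to 100%.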

Compound 4, a percentage reported as activity, at one concentration (the size of the read-out at that concentration, not a potency): 94%
Beside the measured number, compound 4's estimate is 4 percentage points below it; the measured number falls inside the stated range.
By their numbers in this assay, from the lowest: compound 2; then compounds 4, 1 and 3 (each within the scatter of the next).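

On an aromatic carbon, trifluoromethyl in place of a chain changes little in this assay against pentyl or ethyl, with a number 4 percentage points lower from compound 3 to compound 4 (within the scatter) and a number 1 percentage points lower from compound 1 to compound 4 (within the scatter) both read as no real shift. Among these compounds, only the exchange for butyl stands apart: a number 22 percentage points higher from compound 2 to compound 4 (beyond the scatter) is the one step of the three beyond the scatter, so butyl is the exception here and trifluoromethyl is not. Nothing available bears on the reason for this result.

Open remains whether butyl alone gives the lower number, or whether a propyl chain, a hexyl chain or an amine on the same aromatic carbon would join it.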